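This account rests on a few compounds, and the source may have more. Where it says the series, first, only, none or still open, it means among the compounds named here.

Series notes: three aryl-propanoic acids bearing an alkyne substituent on the shared core, all measured in a functional assay on 1321-N1 cells for agonist activity at Free fatty acid receptor 1 (Homo sapiens), read by calcium flux, with a stated time of 0.4 s (a lower number here means a smaller maximal response, a higher number a larger maximal response), and one further analogue awaiting the same measurement.

Compound 1 `CC(C)=C(C)C#Cc1ccc(CCC(=O)O)cc1` gives in this assay a value of 105%. Compound 2 `C/C=C(/C)C#Cc1ccc(CCC(=O)O)c(F)c1` gives 103% in this assay, a number within the scatter of compound 1, so the two are not distinguished. Compound 3 `O=C(O)CCc1ccc(C#CCCc2ccccc2)cc1`, which carries a saturated two-carbon link to a phenyl group on the alkyne instead of an alkenyl group, gives 128% in this assay, beyond the scatter above compound 1. Compound 1 thus stands second highest of the three, separated clearly only from compound 3.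

Compound 4 `C=C(C)C#Cc1ccc(CCC(=O)O)cc1` differs from compound 1 by 1-methylethenyl in place of 1,2-dimethylprop-1-en-1-yl on a triple-bonded carbon. Among the compounds with values here, the alkenyl substituent is retained but shortened; no measured pair in the set shows the effect of such a trimming, so no step is known. Compounds 1 and 2, with different alkenyl groups, sit within the scatter of each other, and on that basis the step of a number 7 percentage points lower from compound 1 to compound 4 (within the scatter) is expected to be no larger than the scatter, in either direction. For compound 4 the efficacy in this assay is estimated at 98%, with a range from 78% to 120%.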

Compound 4, largest response reached (reported as efficacy), in percent of the reference or control that the assay uses: 108%
Beside the measured number, compound 4's estimate is 10 percentage points below it; low and high end bracket the measured number.
By their numbers in this assay, from the lowest: compounds 2, 1 and 4 (each within the scatter of the next); then compound 3.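

In this assay the series now has its first direct step at this position: a number 3 percentage points higher from compound 1 to compound 4 (within the scatter) with 1-methylethenyl in place of 1,2-dimethylprop-1-en-1-yl on a triple-bonded carbon. The alkenyl group can thus go from 5 heavy atoms to 3 with no maximal response that can be told apart from that of compound 1, so this trimming leaves the read-out unchanged within the scatter. Nothing in the available data offers an explanation for this result.

From the compounds shown here alone, it remains open whether the double bond matters at this place, which a saturated group such as isopropyl or tert-butyl on the triple-bonded carbon would test. Also open, going by these compounds, is which part of the phenyl-bearing chain goes with the value of compound 3 at 128% in this assay and whether a phenyl group set directly on the alkyne would give a similar number.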